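A Single Methyl Added to a Potent Growth Inhibitor

The source may hold more compounds than are shown below. What is called first, only, known or untested is meant among the compounds shown, and "the series" means these compounds.

Of the compounds shown here, two have been measured so far in a functional assay on HeLa cells (Homo sapiens) for inhibition, read by sulforhodamine B assay, with a stated time of 48 h; a higher number here means a weaker inhibitor of growth, a lower number a stronger inhibitor of growth. Compound 1 `Cc1ccn2c(CN3CCCCC3)c(-c3ccccc3)nc2n1` gives 1710 nM. Compound 2 `CC(C)(C)c1nc2ncccn2c1CN1CCCCC1` gives 30 nM, the lower of the two numbers and clearly beyond the scatter, which makes it the stronger inhibitor of growth in this pair.

Compound 3 `Cc1ccn2c(CN3CCCCC3)c(C(C)(C)C)nc2n1` departs from compound 2 by one small change, methyl in place of hydrogen on an aromatic carbon, next to the ring nitrogen of the six-membered aromatic ring with 2 nitrogen. Among the measured compounds shown here, no measured pair isolates this change, so its size in this assay is not known directly. A modest rise in the number, meaning slightly weaker inhibition, is expected, with the estimated 1.8-fold higher number from compound 2 to compound 3 (0.26 log units; within the scatter) lying near the edge of the scatter. For compound 3 the estimated value is 55 nM, with an expected range of 15 nM to 220 nM.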

Compound 3, concentration for 50% growth inhibition: 450 nM
Beside the measured number, compound 3's estimate is 8.2-fold (0.91 log units) below it, and the stated range ends below it.
By their numbers in this assay, from the lowest: compound 2; then compound 3; then compound 1.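

In this assay, this position proves far from tolerant: methyl in place of hydrogen on an aromatic carbon, next to the ring nitrogen, gives a 15-fold higher number from compound 2 to compound 3 (1.18 log units; beyond the scatter), so one added carbon atom here is enough to weaken growth inhibition well beyond the scatter. With that methyl present in both compounds, tert-butyl in place of phenyl gives a 3.8-fold lower number from compound 1 to compound 3 (0.58 log units; beyond the scatter), a modest step. No measurement shown here accounts for the size of the methyl step.

The compounds shown leave open whether chlorine, a methoxy group or an amine on this carbon would behave as methyl does. They also leave open whether the step from phenyl to tert-butyl keeps its size with hydrogen in place of the methyl.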